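Replacing the urea arm: compound 1 to compound 3

The source may hold more compounds than are shown below. What is called first, only, known or untested is meant among the compounds shown, and "the series" means these compounds.

Measured so far:
compound 1, `COc1cc(Cl)cc(-c2nn(-c3cccc(NC(=O)Nc4ccc(Cl)c(C(F)(F)F)c4)c3)cc2-c2ccncc2)c1`: 91%
compound 2, `COc1cc(Cl)cc(-c2nn(-c3cccc(NC(=O)Nc4cc(C(F)(F)F)cc(C(F)(F)F)c4)c3)cc2-c2ccncc2)c1`: 79%

Both compounds were tested in a functional assay on UO-31 cells (Homo sapiens) for inhibition, read by sulforhodamine B assay, with a stated time of 48 h, tested at 0.01 uM; a lower number here means a stronger effect, a higher number a weaker effect of the compound at the concentration tested. On the two numbers available, compound 1 gives 91% and stands as the higher of the pair; compound 2 gives 79%, a number that sits below it by more than the usual scatter, so of these two compound 2 shows the stronger effect at this concentration.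

Compound 3, `COc1cc(Cl)cc(-c2nn(-c3cccc(NC(=O)c4cccc(C(F)(F)F)c4)c3)cc2-c2ccncc2)c1`, has not yet been measured in this assay. It differs from compound 1 in one place: 3-(trifluoromethyl)phenyl in place of (4-chloro-3-(trifluoromethyl)phenyl)amino on a carbonyl carbon. Among the compounds with values here, the two measured compounds share the (phenyl)amino attachment on the carbonyl carbon and differ only in the substitution of that phenyl ring, so nothing measured so far speaks directly to what happens when the amino link is removed and 3-(trifluoromethyl)phenyl sits on the carbonyl carbon instead.

Within the data shown here, with no measured step of this kind to lean on, the expectation for compound 3 rests on compound 1 alone, whose 91% already lies near the weak end of the read-out. Compound 3 is therefore estimated at 92%, with a range from 80% to 104%, and the expected step of a number 1 percentage points higher from compound 1 to compound 3 (within the scatter) is one of no change beyond the scatter.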

Compound 3, a percentage reported as activity, at one concentration (the size of the read-out at that concentration, not a potency): 58%
The estimate for compound 3 lay 34 percentage points above the measured number, and the stated range ends above it.
By their numbers in this assay, from the lowest: compound 3; then compound 2; then compound 1.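

In this assay, placing 3-(trifluoromethyl)phenyl on the carbonyl carbon in place of (4-chloro-3-(trifluoromethyl)phenyl)amino gives a number 33 percentage points lower from compound 1 to compound 3 (beyond the scatter), which here means a stronger effect at the concentration tested. The earlier compounds shown here share the amino attachment and differ only in the substitution of the phenyl ring, whereas this step shows that changing the attachment itself, from a urea arm to an amide arm, can move the read-out by a large amount. Nothing available bears on the reason for this step.

The change removes the amino link and the chloro substituent together, so compound 3 alone cannot show how much of the step belongs to either one. Still open, going by these compounds, is what a methylene link between the carbonyl carbon and the ring would do, and whether 4-chloro-3-(trifluoromethyl)phenyl placed directly on the carbonyl carbon would read like compound 3 or lie closer to compound 1.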